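The source may hold more compounds than are shown below. What is called first, only, known or untested is meant among the compounds shown, and "the series" means these compounds.

Measured compounds:
- compound 1 `O=C(O)CCCSCCN1C(=O)OC[C@@H]1/C=C/[C@@H](O)Cc1ccccc1` — in an assay on CHO cells for displacement of a labelled ligand from prostaglandin E2 receptor EP4 subtype (Mus musculus), read by scintillation counting, with a stated time of 60 min (on this read-out lower numbers stand for stronger inhibition and higher numbers for weaker inhibition), compound 1 gives 4.2 nM
- compound 2 `O=C(O)CCCSCCN1C(=O)SC[C@@H]1/C=C/[C@@H](O)Cc1cccc(C(F)(F)F)c1` — in this assay compound 2 gives 0.97 nM

Of the two measured compounds, compound 1 stands at the higher number. Compound 2 gives the lower number, and the gap between the two lies beyond the usual scatter of this assay; compound 2 differs from compound 1 in more than one place, so no single change can be credited with that gap.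

Compound 3 `COCc1cccc(C[C@H](O)/C=C/[C@H]2COC(=O)N2CCSCCCC(=O)O)c1` differs from compound 1 in one place: methoxymethyl in place of hydrogen on an aromatic carbon. For the measured compounds named here, no measured pair shows this change on its own, and compound 2 carries a different group at the corresponding place alongside a second change, so no direct step is available. On that basis a modest step toward a lower number is expected, with the possibility of no change beyond the scatter. For compound 3 the estimate in this assay is 2.5 nM, with a range from 0.8 nM to 8 nM, which would mean a step of a 1.7-fold lower number from compound 1 to compound 3 (0.23 log units; within the scatter).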

Compound 3, inhibition constant: 7.2 nM
For compound 3 the middle estimate is 2.9-fold (0.46 log units) below the measured one, within the range that was stated.
By their numbers in this assay, from the lowest: compound 2; then compounds 1 and 3 (each within the scatter of the next).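

In this assay, methoxymethyl in place of hydrogen on an aromatic carbon, meta to a large group, gives a 1.7-fold higher number from compound 1 to compound 3 (0.23 log units; within the scatter) and is the first step among these compounds that isolates a change at this position. This position of the six-membered aromatic ring therefore accepts methoxymethyl with no change beyond the scatter, which the two earlier compounds could not show because they differ in more than one place. No supporting measurement bears on this result. The compounds shown leave open whether trifluoromethyl at this position would, as the only change to the core of compound 1, give a step beyond the scatter. They also leave open how a nitrile, an amine or a longer ether chain at this position would read in this assay and whether any of these would differ from methoxymethyl.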